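The source may hold more compounds than are shown below. What is called first, only, known or untested is meant among the compounds shown, and "the series" means these compounds.

Measured compounds:
compound 1, `O=C1c2ccccc2C(=O)N1CCOC(=S)N(C(=O)c1c(Cl)cccc1Cl)c1ccc(Cl)cc1`, 20000 nM
compound 2, `O=C1c2ccccc2C(=O)N1CCOC(=S)N(C(=O)c1ccc(Cl)c(Cl)c1)c1ccc(Cl)cc1`, 35000 nM
compound 3, `Cc1ccc(N(C(=O)c2c(Cl)cccc2Cl)C(=S)OCCN2C(=O)c3ccccc3C2=O)cc1`, 22000 nM

All three were tested in an ADME assay on MT4 cells (Homo sapiens) for cytotoxicity, read by MTT assay; on this read-out lower numbers stand for higher toxicity in this test and higher numbers for lower toxicity in this test. Compound 2 differs from compound 1 by 3,4-dichlorophenyl in place of 2,6-dichlorophenyl on a carbonyl carbon, and this change gave a 1.8-fold higher number from compound 1 to compound 2 (0.24 log units; within the scatter). Compound 3 differs from compound 1 in its core: methyl in place of chloro on an aromatic carbon; in this assay compound 3 and compound 1 give numbers within the scatter of each other. Compound 4, `Cc1ccc(N(C(=O)c2ccc(Cl)c(Cl)c2)C(=S)OCCN2C(=O)c3ccccc3C2=O)cc1`, is not yet measured; it differs from compound 3 by 3,4-dichlorophenyl in place of 2,6-dichlorophenyl on a carbonyl carbon, the same change as that from compound 1 to compound 2, on the same place. Going by the values given here, with only one earlier example to rest on, compound 4 is expected to show a 1.6-fold higher number from compound 3 to compound 4 (0.20 log units; within the scatter) in this assay, a step of about the same size as the earlier one, because that earlier change gave a 1.8-fold higher number from compound 1 to compound 2 (0.24 log units; within the scatter). Compound 4 is therefore estimated at 35000 nM, with a likely range from 18000 nM to 70000 nM.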

Compound 4, half-maximal cytotoxic concentration: 17000 nM
Estimate against measurement, compound 4: 2.1-fold (0.31 log units) above, and the stated range ends above it.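

In this assay, 3,4-dichlorophenyl in place of 2,6-dichlorophenyl on the core of compound 3 gave a 1.3-fold lower number from compound 3 to compound 4 (0.11 log units; within the scatter), and this step cannot be told apart from the earlier one on the core of compound 1: the same change on two cores in this assay, a 1.8-fold higher number (0.24 log units; within the scatter) from compound 1 to compound 2 and a 1.3-fold lower number (0.11 log units; within the scatter) from compound 3 to compound 4, 2.3-fold (0.36 log units) apart, within the scatter of two such steps. Methyl in place of chloro on an aromatic carbon gave a 2.1-fold lower number from compound 2 to compound 4 (0.31 log units; beyond the scatter), a modest step beyond the scatter, yet it too cannot be told apart from its earlier counterpart: the same change on two cores in this assay, a 1.1-fold higher number (0.04 log units; within the scatter) from compound 1 to compound 3 and a 2.1-fold lower number (0.31 log units; beyond the scatter) from compound 2 to compound 4, 2.3-fold (0.36 log units) apart, within the scatter of two such steps. These two comparisons show no measurable dependence of either change on the core, but with one pair of steps each and such small steps, they do not establish that either change carries over reliably.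

What the compounds shown leave open is how an amine or a carboxylic acid in place of that methyl or chloro would read in this assay.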